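Compound 3 to compound 4: ethynyl replaces 1-benzofuran-2-yl

The compounds below may be only part of what the source reports. "The series", "measured", "known", "first", "only" and "open" are said of these compounds alone.

In a functional assay on CCRF-CEM cells (Homo sapiens), read by MTT assay, with a stated time of 72 h (on this read-out higher numbers stand for weaker inhibition and lower numbers for stronger inhibition), compound 1 `C#Cc1cn([C@@H]2O[C@H](CO)[C@@H](O)[C@H]2O)c2ncnc(OC)c12`, which also bears ethynyl, gives a limit, > 20000 nM. Compound 2 `COc1nc(N)nc2c1c(-c1cccs1)cn2[C@@H]1O[C@H](CO)[C@@H](O)[C@H]1O` likewise gives a limit, > 20000 nM. Within the data shown here, compound 3 `COc1nc(N)nc2c1c(-c1cc3ccccc3o1)cn2[C@@H]1O[C@H](CO)[C@@H](O)[C@H]1O` gives 12700 nM, the only actual number so far. Compound 4 `C#Cc1cn([C@@H]2O[C@H](CO)[C@@H](O)[C@H]2O)c2nc(N)nc(OC)c12` brings (ethynyl in place of 1-benzofuran-2-yl on an aromatic carbon), ethynyl in place of 1-benzofuran-2-yl on an aromatic carbon. Among the measured compounds shown here, the one measured step, an at least 1.5-fold lower number from compound 2 to compound 3 (0.19 log units; that floor lies within the scatter), stays within the scatter, so it offers no firm guide to the size of this change. With the limit of compound 1 at > 20000 nM as the only ethynyl reference, a small move towards higher numbers is expected, a 1.3-fold higher number from compound 3 to compound 4 (0.13 log units; within the scatter), not beyond the scatter. The estimate for compound 4 is 17000 nM, with an expected range of 7000 nM to 20000 nM.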

Compound 4, half-maximal inhibitory concentration: > 100000 nM
Compound 4 gave a limit, no number (the forecaster's own chance of this, stated with the estimate: 60%); middle value at least 5.8-fold (0.76 log units) away from the limit.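

In this assay, this position now shows a step beyond the scatter: ethynyl in place of 1-benzofuran-2-yl gives an at least 7.8-fold higher number from compound 3 to compound 4 (0.89 log units; beyond the scatter). Among these compounds, the earlier step here, from thiophen-2-yl to 1-benzofuran-2-yl, stayed within the scatter, so this change is the first at this aromatic carbon with a size clear of it. Compound 4 gives a limit, not a number: the limit of > 100000 nM in this assay, at which 1 of the 4 values shown sits.

The steps to compound 4 from compound 1 and from compound 2 cannot be read. Going by these compounds, whether an aminomethyl group or a longer alkyl chain on this carbon would give a lower number than compound 3 at 12700 nM stays open.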